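Sulfamoylphenyl variant at the aryl position of the shared core

The source may hold more compounds than are shown below. What is called first, only, known or untested is meant among the compounds shown, and "the series" means these compounds.

Measured compounds:
- compound 1 `CCCS(=O)(=O)Nc1ccc(F)c(C(=O)c2n[nH]c3ncc(-c4ccccc4Cl)cc23)c1F`: 9.3%
- compound 2 `CCCS(=O)(=O)Nc1ccc(F)c(C(=O)c2n[nH]c3ncc(-c4ccccc4O)cc23)c1F`: 9%
- compound 3 `CCCS(=O)(=O)Nc1ccc(F)c(C(=O)c2n[nH]c3ncc(-c4ccc(Cl)c(C(F)(F)F)c4)cc23)c1F`: 15%

All three share one core and differ only in the aryl group on the aromatic carbon of the fused bicyclic ring. In an assay for binding affinity to dual specificity mitogen-activated protein kinase kinase 4 (Homo sapiens), read by KINOMEscan, tested at 100 nM (on this read-out higher numbers stand for a weaker effect at the one concentration tested and lower numbers for a stronger effect), compound 1 gives 9.3%, compound 2 gives 9% and compound 3 gives 15%. Compound 3 stands at the upper edge of the three numbers, but the steps of a number 5.7 percentage points higher from compound 1 to compound 3 (within the scatter) and a number 6 percentage points higher from compound 2 to compound 3 (within the scatter) both lie within the scatter, so the three compounds cannot be told apart on this read-out; the step of a number 0.3 percentage points lower from compound 1 to compound 2 (within the scatter) is likewise within the scatter.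

Compound 4 `CCCS(=O)(=O)Nc1ccc(F)c(C(=O)c2n[nH]c3ncc(-c4ccc(S(N)(=O)=O)cc4Cl)cc23)c1F` is not yet measured. Relative to compound 3 the change is 2-chloro-4-sulfamoylphenyl in place of 4-chloro-3-(trifluoromethyl)phenyl on an aromatic carbon. Going by the values given here, the steps that bear on it are those that exchange the aryl group at this same carbon, and none of them moved the number beyond the scatter. Among the compounds with values here, nothing among the measured compounds carries a sulfamoyl group, so the expectation rests on the indifference of the read-out to the aryl exchanges seen so far. For compound 4 a step of a number 1 percentage points lower from compound 3 to compound 4 (within the scatter) is expected, that is no change beyond the scatter. Compound 4 is therefore estimated at 14%, in the range 4% to 40%.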

Compound 4, a percentage reported as activity, at one concentration (the size of the read-out at that concentration, not a potency): 3.4%
For compound 4 the middle estimate is 10.6 percentage points above the measured one; the whole stated range lies above it.
By their numbers in this assay, from the lowest: compounds 4, 2, 1 and 3 (each within the scatter of the next, the first and the last beyond it).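

In this assay, the aryl position, where no exchange had yet moved the number beyond the scatter, now gives one such step, a number 11.6 percentage points lower from compound 3 to compound 4 (beyond the scatter), when 2-chloro-4-sulfamoylphenyl replaces 4-chloro-3-(trifluoromethyl)phenyl. The same group does not separate compound 4 from the other two compounds, with a number 5.9 percentage points lower from compound 1 to compound 4 (within the scatter) and a number 5.6 percentage points lower from compound 2 to compound 4 (within the scatter), so the sulfamoyl is tolerated on the 2-chlorophenyl ring, but only the two ends of the series can be told apart on this read-out. No measurement shown gives a reason for the step.

Whether that step reflects the sulfamoyl entering or the 4-chloro-3-(trifluoromethyl)phenyl leaving remains unresolved, as compound 4 and compound 1 cannot be told apart. Also open, as far as these compounds go, is whether a carboxylic acid, an amine or a methylsulfonyl group in place of the sulfamoyl would read the same, and what the chloro contributes when a plain 4-sulfamoylphenyl is compared with the 2-chloro-4-sulfamoylphenyl of compound 4.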